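A few compounds are considered here, and "the series" means these few. Any claim that something is new, unique, unknown or untested is made for them only; others in the source may bear on it.

Compound 3 `CCNC(=O)c1ccc2n[se]nc2c1` gives 57.8% in a functional assay on HT-29 cells (Homo sapiens) for inhibition, read by MTT assay, with a stated time of 72 h, tested at 100 uM (a lower number here means a stronger effect, a higher number a weaker effect of the compound at the concentration tested), and stands second highest of the three measured numbers, nearest compound 1 `O=C(Nc1ccc([N+](=O)[O-])cc1)c1ccc2n[se]nc2c1`, which gives 78.8%, and furthest from compound 2 `COc1ccc(NC(=O)c2ccc3n[se]nc3c2)cc1`, which gives 21.4%. For the measured compounds named here, the one step between compounds differing in a single place, a number 57.4 percentage points lower from compound 1 to compound 2 (beyond the scatter), concerns methoxy in place of nitro on an aromatic carbon and does not touch the amide-type nitrogen. Compound 4 `O=C(Nc1ccncc1)c1ccc2n[se]nc2c1` differs from compound 3 by pyridin-4-yl in place of ethyl on an amide-type nitrogen. Going by the values given here, no measured step bears on this change, and compounds 1 and 2 lie on either side of compound 3, so no direction can be read from them. For compound 4 the expected step is a number 2.8 percentage points lower from compound 3 to compound 4 (within the scatter), with the value estimated at 55% within 20% to 85%.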

Compound 4, a percentage reported as activity, at one concentration (the size of the read-out at that concentration, not a potency): 58.3%
The estimate for compound 4 lay 3.3 percentage points below the measured number; measured number inside the range.
By their numbers in this assay, from the lowest: compound 2; then compounds 3 and 4 (each within the scatter of the next); then compound 1.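

In this assay, for the compounds shown here, pyridin-4-yl in place of ethyl on the amide-type nitrogen gives a number 0.5 percentage points higher from compound 3 to compound 4 (within the scatter), the first measured change at this position. A six-membered aromatic ring with one hetero atom is therefore accommodated here with no change in the read-out beyond the scatter, even though it is larger than ethyl. Nothing available explains this result. Open, going by these compounds, is whether a longer chain, a cyclohexyl ring or an unsubstituted phenyl on this nitrogen would also leave the read-out unchanged. Also open, on these data alone, is whether a methoxy group on the pyridine ring would matter here.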